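A few compounds are considered here, and "the series" means these few. Any claim that something is new, unique, unknown or untested is made for them only; others in the source may bear on it.

Within the data shown here, in a functional assay on KB cells (Homo sapiens) for antiproliferative activity, read by sulforhodamine B assay, with a stated time of 3 days (on this read-out higher numbers stand for an effect only at larger amounts of compound and lower numbers for an effect already at smaller amounts), only two compounds have numbers so far. Compound 2 (`CCC1=C(O)c2c(oc(-c3ccc(C)c(C)c3)cc2=O)C(CC)(CC)C1=O`) gives 35.5 uM and compound 1 (`CCC1=C(O)c2c(oc(-c3ccc(OC)cc3)cc2=O)C(CC)(CC)C1=O`) gives 17.7 uM, so the two lie within the usual scatter of each other and cannot be told apart. Compound 3 (`CCC1=C(O)c2c(oc(-c3ccc(OC)cc3C)cc2=O)C(CC)(CC)C1=O`) has not yet been measured. It departs from compound 2 in one place on the shared core, with 4-methoxy-2-methylphenyl in place of 3,4-dimethylphenyl on an aromatic carbon. Among the measured compounds shown here, the one measured step that bears on this change is a 2.0-fold higher number from compound 1 to compound 2 (0.30 log units; within the scatter), which put 3,4-dimethylphenyl in place of 4-methoxyphenyl and stayed within the scatter. For the measured compounds named here, the incoming group carries the methoxy found in compound 1, along with an extra methyl whose contribution no measured step shows. Going by the values given here, with so small a step as the only guide, no change beyond the scatter is expected in this assay. The estimate amounts to a 1.5-fold lower number from compound 2 to compound 3 (0.17 log units; within the scatter), an expected step that stays within the scatter. For compound 3 the expected value is 24 uM, with an estimated range from 10 uM to 58 uM.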

Compound 3, concentration for half-maximal effect: 20.9 uM
For compound 3 the middle estimate is 1.1-fold (0.06 log units) above the measured one; low and high end bracket the measured number.
By their numbers in this assay, from the lowest: compounds 1, 3 and 2 (each within the scatter of the next).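

In this assay, putting 4-methoxy-2-methylphenyl in place of 3,4-dimethylphenyl, on the aromatic carbon next to the ring oxygen, gives a 1.7-fold lower number from compound 2 to compound 3 (0.23 log units; within the scatter), so this change too cannot be told apart from repeat-measurement noise. Among these compounds, the new compound also isolates the extra methyl, which no earlier step could show: methyl in place of hydrogen on the aromatic carbon of the phenyl group gives a 1.2-fold higher number from compound 1 to compound 3 (0.07 log units; within the scatter), so adding this one small group to the 4-methoxyphenyl of compound 1 has no effect that this assay can resolve. Across these three compounds, then, the phenyl groups tried at this position give numbers that lie within the scatter of one another, and no other kind of measurement is at hand to say why.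

On these data alone, what remains open is whether a group of another kind on this phenyl ring, such as an amine or a carboxylic acid, would shift the number beyond the scatter. The compounds shown also leave the ethyl groups of the shared core untouched, so the effect of a longer chain in their place is unknown.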